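A few compounds are considered here, and "the series" means these few. Any claim that something is new, unique, unknown or untested is made for them only; others in the source may bear on it.

Compound 1 `NC(=O)NC(=O)c1cc(NC(=O)CBr)ccc1F`: < 10 nM (a limit)
Compound 2 `COC(=O)c1cc(NC(=O)CBr)cc(C(=O)NC(N)=O)c1`: 1300 nM
Compound 3 `NC(=O)NC(=O)c1cc(NC(=O)CI)ccc1F`: < 10 nM (a limit)

In a functional assay on CCRF-CEM cells (Homo sapiens) for antiproliferative activity, read by trypan blue exclusion, with a stated time of 72 h (on this read-out lower numbers stand for stronger inhibition and higher numbers for weaker inhibition), compound 1 gives < 10 nM, which is a limit of the assay and not a number. Compound 3 likewise gives < 10 nM, again a limit. For the measured compounds named here, compound 2 is the only one with a plain number, at 1300 nM. The step from compound 1 to compound 3 is the change (iodo in place of bromo on a saturated chain carbon bound to a carbonyl carbon); its size is a step that the two limits leave unreadable from compound 1 to compound 3 because both compounds sit at the limit of < 10 nM in this assay, at which 2 of the 3 values shown sit. How the core of compound 2 differs from the core of compound 1 is not broken down here. Compound 4 `COC(=O)c1cc(NC(=O)CI)cc(C(=O)NC(N)=O)c1` carries the same change, (iodo in place of bromo on a saturated chain carbon bound to a carbonyl carbon), made on compound 2. Since that change left no readable step between compound 1 and compound 3, the step from compound 2 to compound 4 is expected to be small, a 1.3-fold lower number from compound 2 to compound 4 (0.11 log units; within the scatter). Compound 4 is therefore estimated at 1000 nM, between 400 nM and 3000 nM.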

Compound 4, half-maximal inhibitory concentration: 1910 nM
Estimate against measurement, compound 4: 1.9-fold (0.28 log units) below; the range from low to high includes it.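

In this assay, iodo in place of bromo on the core of compound 2 gives a 1.5-fold higher number from compound 2 to compound 4 (0.17 log units; within the scatter), so on this core the swap makes no readable difference. The same change on the core of compound 1 offers nothing to compare this with, because the values of compound 1 and compound 3 are both limits and not numbers: the limit of < 10 nM in this assay, at which 2 of the 4 values shown sit. The series therefore shows the swap on one core only, and it does not show that the change behaves alike on both cores, since a real difference could lie hidden behind those limits.

The compounds shown leave open what chloro in place of bromo would do. They also leave open what a longer chain carrying the halogen would do on either core.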